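The source may hold more compounds than are shown below. What is called first, only, known or untested is meant among the compounds shown, and "the series" means these compounds.

In a toxicity assay on MDCK cells (Canis lupus familiaris) for cytotoxicity, read by crystal violet staining, with a stated time of 48 h (a higher number here means that more compound is tolerated, a lower number that less compound is tolerated), compound 3 (`CCc1ccc2[nH]c(=O)c(CN(Cc3ccc(OCOC)cc3)Cc3ccc(C(C)(C)C)cc3)cc2c1`) gives > 10000 nM, which is a limit of the assay rather than a number. Two neighbours differ from it in one place. Compound 1 (`CCc1ccc2[nH]c(=O)c(CN(Cc3ccc(F)cc3)Cc3ccc(C(C)(C)C)cc3)cc2c1`) gives > 33000 nM, again a limit. Compound 2 (`COCOc1ccc(CN(Cc2ccc(C(C)(C)C)cc2)Cc2cc3cc(C)ccc3[nH]c2=O)cc1`) gives 6400 nM. The step that the two limits leave unreadable from compound 1 to compound 3 cannot be sized, and the step of an at least 1.5-fold higher number from compound 2 to compound 3 (0.19 log units; that floor lies within the scatter) is small. Compound 4 (`CCc1ccc2[nH]c(=O)c(CN(Cc3ccc(OC(F)F)cc3)Cc3ccc(C(C)(C)C)cc3)cc2c1`) differs from compound 3 only by difluoromethyl in place of methoxymethyl on an oxygen on an aromatic ring. Going by the values given here, no measured step follows this change, so the expectation rests on compound 3 alone, whose limit > 10000 nM suggests no step beyond the scatter. Compound 4 is therefore expected to give about 15000 nM in this assay, within 5000 nM to 50000 nM, a step that the limit leaves unreadable from compound 3 to compound 4.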

Compound 4, half-maximal cytotoxic concentration: > 5000 nM
Compound 4 was reported as a limit; the forecaster's own chance of this, stated with the estimate: 60%; the middle value does not contradict the limit.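

Compound 4, like compound 1 and compound 3, is reported only as a limit, and no new step can be read among them. On these data alone, how far these three actually differ in this assay stays open.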